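The source may hold more compounds than are shown below. What is called first, only, known or untested is meant among the compounds shown, and "the series" means these compounds.

Measured in a functional assay on P388 cells (Mus musculus) for antiproliferative activity, with a stated time of 72 h; a lower number here means that less compound is needed, a higher number that more compound is needed for the effect:
- compound 1 `Cc1cn([C@H]2C[C@H](CF)[C@@H](CO)O2)c(=O)[nH]c1=O`: > 100 uM (a limit)
- compound 2 `Cc1cn([C@@H]2O[C@H](CO)[C@@H](CF)[C@H]2O)c(=O)[nH]c1=O`: > 100 uM (a limit)

Compound 2 stands only at a limit, > 100 uM, and has no number. Within the data shown here, the series so far shows (the limit of > 100 uM in this assay, at which 2 of the 2 values shown sit).

Compound 3 `Cc1cn([C@@H]2O[C@H](CO)[C@@H](CN)[C@H]2O)c(=O)[nH]c1=O` differs from compound 2 by amino in place of fluoro on a saturated chain carbon bound to a saturated ring carbon, with amino in place of fluoro. Among the measured compounds shown here, the only measured step is a step that the two limits leave unreadable from compound 1 to compound 2, and it gives no size to carry over. No step beyond the scatter is therefore expected in this assay, in either direction.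

The expected step is a number no higher from compound 2 to compound 3 (the limit leaves the size open).

For compound 3 the estimated value is 100 uM, with an expected range of 40 uM to 250 uM.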

Compound 3, concentration for half-maximal effect: > 100 uM
Compound 3: no number, only a limit; the forecaster's own chance of this, stated with the estimate: 75%; the middle value sits exactly at the limit.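

Compound 2 and compound 3 both stand only at limits in this assay, so no step can be read between them. The compounds shown leave open whether any change on the shared core gives a readable number, and the series so far rests at one point: the limit of > 100 uM in this assay, at which 3 of the 3 values shown sit.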